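Acyl to urea exchange in the iodophenyl sulfonate series

The source may hold more compounds than are shown below. What is called first, only, known or untested is meant among the compounds shown, and "the series" means these compounds.

Three acylated anilines on one shared core have been measured in a functional assay on MCF7 cells (Homo sapiens) for antiproliferative activity, read by sulforhodamine B assay, with a stated time of 48 h; a higher number here means a weaker inhibitor, a lower number a stronger inhibitor. Compound 1 `CCCCCC(=O)Nc1ccc(S(=O)(=O)Oc2ccccc2I)cc1` gives 10000 nM, compound 2 `CC(C)(C)C(=O)Nc1ccc(S(=O)(=O)Oc2ccccc2I)cc1` gives 6600 nM, and compound 3 `O=C(CCCCl)Nc1ccc(S(=O)(=O)Oc2ccccc2I)cc1` gives 6300 nM. Among the compounds with values here, compound 3 holds the lowest number of the three, yet it sits within the scatter of both others: the steps of a 1.6-fold lower number from compound 1 to compound 3 (0.20 log units; within the scatter) and a 1.0-fold lower number from compound 2 to compound 3 (0.02 log units; within the scatter), like a 1.5-fold lower number from compound 1 to compound 2 (0.18 log units; within the scatter), all fall inside the usual spread, so no compound among the three can be called more active than another.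

Compound 4 `CCNC(=O)Nc1ccc(S(=O)(=O)Oc2ccccc2I)cc1` is the next entry: ethylamino in place of 3-chloropropyl on a carbonyl carbon. Read one bond further out, (3-chloropropyl)carbonyl becomes ethylcarbamoyl. Within the data shown here, no measured pair covers such an exchange; the three known steps vary only the carbon group on the carbonyl carbon, and none of them produced a step beyond the scatter. On these data alone, the change to compound 4 is of a different kind and is untested here, so the expectation rests on the flat picture seen so far. For compound 4 the step of a 1.1-fold higher number from compound 3 to compound 4 (0.05 log units; within the scatter) is expected to stay within the scatter. Compound 4 is estimated at 7000 nM in this assay, with a range from 3000 nM to 20000 nM.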

Compound 4, half-maximal inhibitory concentration: 1100 nM
Estimate against measurement, compound 4: 6.4-fold (0.80 log units) above; the whole stated range lies above it.
By their numbers in this assay, from the lowest: compound 4; then compounds 3, 2 and 1 (each within the scatter of the next).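

In this assay the ethylamino group on the carbonyl carbon sets compound 4 apart from all three earlier compounds (a 5.7-fold lower number from compound 3 to compound 4 (0.76 log units; beyond the scatter); a 6.0-fold lower number from compound 2 to compound 4 (0.78 log units; beyond the scatter); a 9.1-fold lower number from compound 1 to compound 4 (0.96 log units; beyond the scatter)), each step beyond the scatter and each in favour of compound 4, whereas exchanges among pentyl, tert-butyl and 3-chloropropyl gave no step beyond it. This position is therefore not indifferent to what sits on the carbonyl carbon: the flat picture holds only among those three carbon groups, and the first clear shift comes with an exchange that places a nitrogen there and adds a hydrogen-bond donor, turning the acyl series into a urea. No measurement shown here accounts for the shift, and no data on the mechanism bear on it.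

Within the data shown here, the single exchange changes the linking atom and the attached chain together, so the share of each in the shift remains open. A methylamino, propylamino or dimethylamino group at the same place, or an ethoxy group, would separate the contribution of the nitrogen, its hydrogen and the ethyl chain.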